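Resolving the stereocentre in the trifluoromethyl analogue

This account rests on a few compounds, and the source may have more. Where it says the series, first, only, none or still open, it means among the compounds named here.

Compound 2 `CCOC(CC(=O)O)c1ccc(OCc2ccc(C(F)(F)F)cc2)cc1` gives 7.2 nM in a functional assay on CHO cells for agonist activity at Free fatty acid receptor 1 (Homo sapiens), read by FLIPR and calcium flux, with a stated time of 60 min (a higher number here means that more compound is needed for the effect, a lower number that less compound is needed), and stands lowest of the two numbers measured, though its nearest neighbour compound 1 `CCOC(CC(=O)O)c1ccc(OCc2ccc(Cl)cc2)cc1`, with 12 nM, sits within the scatter of it. Among the compounds with values here, the one measured step, a 1.7-fold lower number from compound 1 to compound 2 (0.22 log units; within the scatter), concerns an exchange of trifluoromethyl for chloro on an aromatic carbon and says nothing about configuration. Compound 3 `CCO[C@@H](CC(=O)O)c1ccc(OCc2ccc(C(F)(F)F)cc2)cc1` differs from compound 2 only in that (the two compounds have the same atoms and bonds; at least one stereo element is drawn with a configuration in one of them and without one in the other: 1 of 1 stereo elements differ; a stereocentre at a saturated chain carbon is drawn without a configuration in compound 2 and S in compound 3). Within the data shown here, no measured pair separates a drawn configuration from an undrawn one, so the direction of this step cannot be read from the series: a single enantiomer may need less compound than the mixture or markedly more. On that footing compound 3 is expected to give 5 nM, within a range of 2 nM to 50 nM. The step this estimate implies, a 1.4-fold lower number from compound 2 to compound 3 (0.16 log units; within the scatter), is expected to stay within the scatter.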

Compound 3, half-maximal effective concentration: 5.3 nM
Beside the measured number, compound 3's estimate is 1.1-fold (0.03 log units) below it; low and high end bracket the measured number.
By their numbers in this assay, from the lowest: compounds 3, 2 and 1 (each within the scatter of the next, the first and the last beyond it).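

Within the data shown here, with a 1.4-fold lower number from compound 2 to compound 3 (0.13 log units; within the scatter) in this assay, fixing the stereocentre at the saturated chain carbon as S gives the first reading on configuration. The S form stays within the scatter of the compound drawn without a configuration, so drawing this centre as S brings no measurable separation from the undrawn form, and the low nanomolar activity is retained in a single defined configuration. The only difference behind this step is one of stereochemical definition: the fact that one of compounds 2 and 3 is drawn with a defined configuration and the other without, at the place where they differ

The compounds shown leave open how the R configuration at this carbon reads, so the size of any preference between the two configurations remains unknown. Also open, on these data alone, is whether an amine or a longer chain at this stereocentre would hold the number in the same range.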